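Compound 4 Changes the Group on a Ring Nitrogen

The source may report more compounds than this note shows. Statements on the series, on what has been measured and on what is new or still open speak of the compounds shown alone.

Three measured compounds share one core and differ only in the group on an amine nitrogen in a ring. In a functional assay on isolated protein for inhibition of Glucose-dependent insulinotropic receptor (Rattus norvegicus), read by HTRF and cAMP accumulation (a higher number here means that more compound is needed for the effect, a lower number that less compound is needed), compound 1 `Cc1nc(S(C)(=O)=O)ccc1Oc1ncnc(OC2CCN(C(=O)O[C@H](C)C(F)(F)F)CC2)c1F` gives 110 nM. In this assay compound 2 `Cc1nc(S(C)(=O)=O)ccc1Oc1ncnc(OC2CCN(C(=O)SC(C)C)CC2)c1F` gives 41.3 nM, and compound 3 `Cc1nc(S(C)(=O)=O)ccc1Oc1ncnc(OC2CCN(C(=S)OC3(C)CC3)CC2)c1F` gives 48.8 nM. Among these three numbers compound 3 stands second highest: the step of a 1.2-fold higher number from compound 2 to compound 3 (0.07 log units; within the scatter) is small, while a 2.3-fold lower number from compound 1 to compound 3 (0.35 log units; beyond the scatter) is the widest gap.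

Compound 4 `Cc1nc(S(C)(=O)=O)ccc1Oc1ncnc(OC2CCN(C(=O)c3ncc(Cl)cn3)CC2)c1F` has not yet been measured. The change from compound 3 is a group of 9 heavy atoms (5 carbon, 2 nitrogen, 1 oxygen, 1 chlorine; one six-membered aromatic ring with 2 hetero atoms) in place of a group of 7 heavy atoms (5 carbon, 1 oxygen, 1 sulfur; one three-membered non-aromatic ring of carbon only), on an amine nitrogen in a ring.

Every step measured so far alters this same nitrogen substituent: a 2.7-fold lower number from compound 1 to compound 2 (0.43 log units; beyond the scatter), a 2.3-fold lower number from compound 1 to compound 3 (0.35 log units; beyond the scatter), and a 1.2-fold higher number from compound 2 to compound 3 (0.07 log units; within the scatter). None moved the number by more than a modest amount. Among the measured compounds shown here, the entering group, with its six-membered aromatic ring, resembles none of the measured groups, so a modest step in either direction or none beyond the scatter is expected. Compound 4 is expected to give about 55 nM, between 20 nM and 160 nM. The expected step is a 1.1-fold higher number from compound 3 to compound 4 (0.05 log units; within the scatter).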

Compound 4, half-maximal effective concentration: 30.9 nM
Compound 4: middle estimate off by 1.8-fold (0.25 log units), on the high side, within the range that was stated.
By their numbers in this assay, from the lowest: compounds 4, 2 and 3 (each within the scatter of the next); then compound 1.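

On this ring nitrogen, a carbonyl carrying an aromatic ring, 5-chloropyrimidin-2-yl, fits the same range as the sulfur-containing groups in this assay: both comparisons (a 1.6-fold lower number from compound 3 to compound 4 (0.20 log units; within the scatter); a 1.3-fold lower number from compound 2 to compound 4 (0.13 log units; within the scatter)) stay inside the scatter, so compounds 2, 3 and 4 cannot be told apart. The step from the 1-(trifluoromethyl)ethoxy carbamate (a 3.6-fold lower number from compound 1 to compound 4 (0.55 log units; beyond the scatter)) lies beyond the scatter, so a group with no resemblance to the sulfur-containing groups also gives a lower number than that carbamate. Nothing at hand explains why such different groups give such similar numbers.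

From the compounds shown here alone, what the chlorine contributes remains open, as does whether a plain pyrimidine, phenyl or pyridine ring would give a similar number. Going by these compounds, whether the carbonyl itself matters also remains open, and a benzyl or sulfonyl group on this nitrogen would address that.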